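A few compounds are considered here, and "the series" means these few. Any claim that something is new, unique, unknown or untested is made for them only; others in the source may bear on it.

Series on a shared core bearing a trimethoxyphenyl group; two members have been measured. Compound 1 `COc1cc(-c2nnc3n2NC(c2cccs2)C(C(=O)c2ccc(Cl)cc2)S3)cc(OC)c1OC` gives 20100 nM in a functional assay on A549 cells (Homo sapiens) for cytotoxicity, read by MTT assay, with a stated time of 48 h; on this read-out lower numbers stand for stronger inhibition and higher numbers for weaker inhibition. Compound 2 `COc1cc(-c2nnc3n2NC(c2ccco2)C(C(=O)c2ccc(C(F)(F)F)cc2)S3)cc(OC)c1OC` gives 37200 nM in this assay, a number that lies within the usual scatter of the number for compound 1, so the two cannot be ordered. Compound 3 `COc1cc(-c2nnc3n2NC(c2ccco2)C(C(=O)c2ccc(F)cc2)S3)cc(OC)c1OC` is not yet measured. It differs from compound 2 by fluoro in place of trifluoromethyl on an aromatic carbon. With only these two numbers, no step beyond the scatter is expected, and the step of a 1.5-fold lower number from compound 2 to compound 3 (0.17 log units; within the scatter) is estimated as small. Compound 3 is expected at 25000 nM, between 10000 nM and 60000 nM.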

Compound 3, half-maximal inhibitory concentration: 53700 nM
Estimate against measurement, compound 3: 2.1-fold (0.33 log units) below; the measured number falls inside the stated range.
By their numbers in this assay, from the lowest: compounds 1, 2 and 3 (each within the scatter of the next, the first and the last beyond it).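

Within the data shown here, the change from 4-(trifluoromethyl)phenyl to 4-fluorophenyl gives a 1.4-fold higher number from compound 2 to compound 3 (0.16 log units; within the scatter) in this assay, the first step that differs in one place only. At this aromatic carbon, going from 4 heavy atoms to 1 therefore leaves the two compounds indistinguishable in this read-out. Nothing measured on these compounds explains the size of this step.

Open, from the compounds shown here alone, is whether an amine or a carboxylic acid on this aromatic carbon would give a step beyond the scatter. Also open, going by these compounds, is whether the same change gives a step of this size when the rest of the molecule differs.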